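Notes on a halogen swap in a growth-inhibition series

A few compounds are considered here, and "the series" means these few. Any claim that something is new, unique, unknown or untested is made for them only; others in the source may bear on it.

Measured so far in a functional assay on DU-145 cells (Homo sapiens) for inhibition, read by trypan blue exclusion, with a stated time of 96 h; on this read-out lower numbers stand for stronger inhibition of growth and higher numbers for weaker inhibition of growth:
compound 1 `Cc1ccc(S(=O)(=O)/C(=C/c2sccc2C)C(=O)c2ccc(Cl)cc2)cc1` gives 10000 nM
compound 2 `Cc1ccc(CS(=O)(=O)/C(=C/c2ccc(Br)cc2)C(=O)c2ccc(Cl)cc2)cc1` gives 25000 nM
compound 3 `COc1cc(OC)c(/C=C(\C(=O)c2ccc(Cl)cc2)S(=O)(=O)c2ccc(Br)cc2)c(OC)c1` gives only the assay limit > 100000 nM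

Compound 2 stands at the highest of the two numbers in this assay; its nearest neighbour is compound 1, whose number is lower by a gap beyond the scatter. Compound 3 sits at the assay limit of > 100000 nM in this assay, at which 1 of the 3 values shown sits, and gives no number.

Compound 4 `Cc1ccc(CS(=O)(=O)/C(=C/c2ccc(Cl)cc2)C(=O)c2ccc(Cl)cc2)cc1` is not yet measured. It differs from compound 2 by chloro in place of bromo on an aromatic carbon. Going by the values given here, no measured pair shows the effect of this change. Since the two halogens differ by a single heavy atom in the same place, the step of a 1.2-fold higher number from compound 2 to compound 4 (0.08 log units; within the scatter) is expected to stay within the scatter, with no clear direction. Compound 4 is therefore estimated at 30000 nM, between 10000 nM and 90000 nM.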

Compound 4, concentration for 50% growth inhibition: 25000 nM
Beside the measured number, compound 4's estimate is 1.2-fold (0.08 log units) above it; measured number inside the range.
By their numbers in this assay, from the lowest: compound 1; then compounds 2 and 4 (each within the scatter of the next). At a limit, above all of these: compound 3.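

In this assay, going by these compounds alone, this is the first pair that differs in one place, and it gives a direct reading of the 4-bromophenyl to 4-chlorophenyl change: the step runs no change at the digits printed from compound 2 to compound 4 (within the scatter) and stays within the scatter. On the core shared by these two compounds, the read-out does not separate chloro from bromo at this aromatic carbon.

Whether an amine or a carboxylic acid at this place would read differently remains open, as the compounds shown carry only the two halogens here. No measurement shown bears on a reason for this result.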